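The compounds below may be only part of what the source reports. "The series", "measured", "known", "first", "only" and "open" are said of these compounds alone.

Within the data shown here, compound 3 `Cc1ccc(S(=O)(=O)N(Cc2nnc(Cc3cccc(Cl)c3)o2)c2cccc(Cl)c2C)cc1` gives 2000 nM in a functional assay on CHO cells for antagonist activity at prostaglandin E2 receptor EP1 subtype (Homo sapiens), read by FLIPR and calcium flux (a lower number here means a stronger inhibitor, a higher number a weaker inhibitor), the highest of the three numbers measured so far; compound 1 `CCOc1ccc(Cc2nnc(CN(c3cccc(Cl)c3C)S(=O)(=O)c3ccc(C)cc3)o2)cc1` gives 50.1 nM and compound 2 `Cc1ccc(S(=O)(=O)N(Cc2nnc(Cc3ccc(C(F)(F)F)cc3)o2)c2cccc(Cl)c2C)cc1` gives 158 nM in this assay. The step to compound 4 `Cc1ccc(S(=O)(=O)N(Cc2nnc(Cc3c(Cl)cccc3Cl)o2)c2cccc(Cl)c2C)cc1` is 2,6-dichlorophenyl in place of 3-chlorophenyl on a saturated chain carbon bound to an aromatic carbon. The same place has been varied twice already: a 40-fold higher number from compound 1 to compound 3 (1.60 log units; beyond the scatter) and a 13-fold higher number from compound 2 to compound 3 (1.10 log units; beyond the scatter), both large, so the aryl group carried on that chain carbon plainly moves the number in this assay. Among the measured compounds shown here, neither of those steps, however, tests the dichlorophenyl pattern now entering, and no measured pair shows the direction of such a change; the earlier steps only show that this ring can shift the number widely. The expectation for compound 4 is therefore a number near that of compound 3 with wide uncertainty, a 1.3-fold lower number from compound 3 to compound 4 (0.12 log units; within the scatter), estimated at 1500 nM between 400 nM and 6000 nM.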

Compound 4, inhibition constant: 501 nM
Compound 4: the middle estimate sits 3.0-fold (0.48 log units) above what was measured, and the stated range covers the measured number.
By their numbers in this assay, from the lowest: compound 1; then compound 2; then compound 4; then compound 3.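

In this assay, 2,6-dichlorophenyl in place of 3-chlorophenyl gives a 4.0-fold lower number from compound 3 to compound 4 (0.60 log units; beyond the scatter), so a chlorinated ring at this place need not sit at the weak end of the series. The gain stays partial, with a 3.2-fold higher number from compound 2 to compound 4 (0.50 log units; beyond the scatter) and a 10-fold higher number from compound 1 to compound 4 (1.00 log units; beyond the scatter), and 4-(trifluoromethyl)phenyl and 4-ethoxyphenyl both remain ahead of 2,6-dichlorophenyl. Nothing available accounts for these shifts.

Open, as far as these compounds go, is whether the second chlorine or the chlorine pattern carries the change. Also open, from the compounds shown here alone, is how an aryl ring bearing methoxy, an amine or a carboxylic acid would compare with compound 1.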